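The compounds below may be only part of what the source reports. "The series", "measured", "known", "first", "only" and "open" are said of these compounds alone.

Measured so far:
- compound 1 `Cc1ccc2[nH]c(-c3ccc(-c4ccc(-c5ccc(N(C)C)cc5)cc4)cc3)nc2c1`: 7200 nM
- compound 2 `Fc1ccc(-c2ccc(-c3ccc(-c4nc5ccccc5[nH]4)cc3)cc2)cc1`: 100000 nM

In a functional assay on ZR-75-1 cells (Homo sapiens) for inhibition, read by sulforhodamine B assay (on this read-out lower numbers stand for stronger inhibition of growth and higher numbers for weaker inhibition of growth), compound 2 has the higher of the two numbers, at 100000 nM. Compound 1 sits lower at 7200 nM, and that gap lies beyond the scatter. These two compounds differ in more than one place, so they give no clean measure of what a single change does.

Compound 3 `FC(F)(F)Oc1ccc(-c2ccc(-c3ccc(-c4nc5ccccc5[nH]4)cc3)cc2)cc1` keeps the structure of compound 2 but has trifluoromethoxy in place of fluoro on an aromatic carbon, para to a large group (trifluoromethoxy in place of fluoro on an aromatic carbon).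

With compound 2 at 100000 nM, a moderate move towards a lower number in this assay is expected, although a result within the scatter would not surprise. The estimate amounts to a 3.3-fold lower number from compound 2 to compound 3 (0.52 log units; beyond the scatter). The expected value for compound 3 is 30000 nM, with a range from 6000 nM to 100000 nM.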

Compound 3, concentration for 50% growth inhibition: 100000 nM
Compound 3: the middle estimate sits 3.3-fold (0.52 log units) below what was measured; the range from low to high includes it.
By their numbers in this assay, from the lowest: compound 1; then compounds 2 and 3 (each within the scatter of the next).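

Going by these compounds alone, putting trifluoromethoxy in place of fluoro on this aromatic carbon gives no change at the digits printed from compound 2 to compound 3 (within the scatter) in this assay, and this is the first reading of a single change at this position, since compounds 1 and 2 differ in more than one place. Five heavy atoms, including one hydrogen-bond acceptor, now stand where a single fluorine stood, yet the two compounds cannot be told apart on this read-out. No available measurement bears on why this swap leaves the number as it is.

As far as these compounds go, whether an amine or a carboxylic acid at this position would give a lower number in this assay remains open. Also open, from the compounds shown here alone, is whether the same swap would give the same result on the core of compound 1, which reads 7200 nM.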